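Rat cell toxicity across a small set of related analogues

The source may hold more compounds than are shown below. What is called first, only, known or untested is meant among the compounds shown, and "the series" means these compounds.

compound 1 `CCOc1cc(/C=N/N=C(\N)CC(O)c2ccc3ccccc3c2)ccc1O`: 78000 nM
compound 2 `N/C(CC(O)c1ccc2ccccc2c1)=N\N=C\c1ccco1`: no result reported
compound 3 `COc1ccc(/C=N/N=C(\N)CC(O)c2cccc3ccccc23)cc1`: 6300 nM

These compounds were tested in an ADME assay on L6 cells (Rattus norvegicus) for cytotoxicity, read by resazurin assay, with a stated time of 72 h; on this read-out higher numbers stand for weaker inhibition and lower numbers for stronger inhibition. In this assay compound 1 gives 78000 nM, while compound 3 gives 6300 nM, the lower number of the two. Compound 2 stands nowhere on these numbers: in this assay compound 2 gives "not determined" (no result reported), so it offers no anchor of its own.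

Compound 4 `N/C(CC(O)c1ccc2ccccc2c1)=N\N=C\c1ccc(F)cc1` is compound 2 with one change: 4-fluorophenyl in place of furan-2-yl on a carbon with a double bond to nitrogen. Within the data shown here, no measured pair shows what this change does in this assay, so its size and direction cannot be read from the data; a shift within the scatter, in either direction, is the plainest expectation. On that basis compound 4 is estimated at 30000 nM in this assay, expected to fall between 7000 nM and 130000 nM.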

Compound 4, half-maximal inhibitory concentration: > 298000 nM
Compound 4 gave a limit, no number (the forecaster's own chance of this, stated with the estimate: 15%); at least 9.9-fold (0.99 log units) between middle value and limit.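

No step can be read between compound 2 and compound 4, since compound 2 has no reported result and compound 4 gives only a limit. As far as these compounds go, what replacing furan-2-yl with 4-fluorophenyl does in this assay stays open.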